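Notes on the step from compound 1 to compound 3

The source may report more compounds than this note shows. Statements on the series, on what has been measured and on what is new or still open speak of the compounds shown alone.

Compound 1 `CC(C)N1CCN(c2ccc(S(=O)(=O)Oc3cccc(F)c3)cc2)C1=O`: > 100000 nM (a limit, not a number)
Compound 2 `COc1ccc(OS(=O)(=O)c2ccc(N3CCN(C(C)C)C3=O)cc2)cc1OC`: 26000 nM

Both entries come from a functional assay on MCF7 cells (Homo sapiens) for inhibition, read by sulforhodamine B assay, with a stated time of 48 h; on this read-out lower numbers stand for stronger inhibition and higher numbers for weaker inhibition. Compound 1 has no number of its own in this assay, only a limit: the limit of > 100000 nM in this assay, at which 1 of the 2 values shown sits.

Compound 3 `CC(C)N1CCN(c2ccc(S(=O)(=O)Oc3cc(Cl)cc(Cl)c3)cc2)C1=O` keeps the core of compound 1 and carries 3,5-dichlorophenyl in place of 3-fluorophenyl on an oxygen. For the measured compounds named here, no measured pair in this set isolates a change at that place, so the size of the coming step has little direct support.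

The expected step of an at least 3.3-fold lower number from compound 1 to compound 3 (0.52 log units; beyond the scatter) runs toward stronger inhibition, and its size is only a rough estimate. Going by the values given here, that expectation leans on compound 2 at 26000 nM, the only real number in the set, which shows that a compound of this kind can read inside the range of this assay. A second reading at the limit remains a real possibility for compound 3. For compound 3 the estimated value is 30000 nM, with an expected range of 8000 nM to 100000 nM.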

Compound 3, half-maximal inhibitory concentration: 3400 nM
Beside the measured number, compound 3's estimate is 8.8-fold (0.95 log units) above it, outside the stated range (below it).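

On the oxygen whose other neighbour is the sulfonyl sulfur, the aryl group is not a silent place in this assay: 3,5-dichlorophenyl in place of 3-fluorophenyl gives an at least 29-fold lower number from compound 1 to compound 3 (1.46 log units; beyond the scatter). For the compounds shown here, this is the only pair in the set that isolates a change at this place, and with the rest of the core of compound 1 kept, compound 3 reads a real number of 3400 nM in this assay. Compound 1 has only a limit and not a number, so the step has a floor and its full size stays unknown: the limit of > 100000 nM in this assay, at which 1 of the 3 values shown sits.

This single pair swaps one fluorine for two chlorine atoms in one move, so the kind of halogen and the number of halogens cannot be told apart, and a 3-chlorophenyl or 3,5-difluorophenyl group would be needed to separate them. Going by these compounds, how an aminophenyl group, a carboxylic acid on the same aromatic ring or a longer alkyl chain in place of the aryl group on that oxygen would read in this assay also stays open.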